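This account rests on a few compounds, and the source may have more. Where it says the series, first, only, none or still open, it means among the compounds named here.

The compounds measured so far:

compound 1, `O=C(NCC=C(c1ccccc1)c1ccccc1)Nc1ccc(Cl)cc1`: in an assay on cell membranes for binding affinity to Cholecystokinin receptor type A (Rattus norvegicus) (a higher number here means a weaker inhibitor, a lower number a stronger inhibitor), compound 1 gives 90 nM
compound 2, `O=C(NCC=C(c1ccccc1)c1ccccc1)c1ccc(Cl)cc1`: in this assay compound 2 gives > 2000 nM

The two share one core, a diphenylethenyl chain joined through a carbonyl to a chlorinated ring. Compound 1 carries a urea, compound 2 an amide. Within the data shown here, the one measured step, an at least 22-fold higher number from compound 1 to compound 2 (1.34 log units; beyond the scatter), is large. For compound 2 the reported value is a limit of the assay and not a number, as it sits at the limit of > 2000 nM in this assay, at which 1 of the 2 values shown sits. Compound 2 therefore stands at the weak end of what this assay can report.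

Compound 3, `O=C(NCC=C(c1ccccc1)c1ccccc1)c1ccc(Cl)c(Cl)c1`, is still to be measured. It differs from compound 2 by a single change: chloro in place of hydrogen on an aromatic carbon. Among the measured compounds shown here, no measured step changes a substituent on that ring; the only step known alters the link at the carbonyl, and so it gives no direct guide to adding a chloro. With compound 2 already at the limit, a value beyond that limit is the most likely outcome for compound 3. Compound 3 is expected to give around 3500 nM, within a range of 800 nM to 20000 nM. The expected step is a step that the limit leaves unreadable from compound 2 to compound 3.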

Compound 3, inhibition constant: 400 nM
Beside the measured number, compound 3's estimate is 8.8-fold (0.94 log units) above it; the whole stated range lies above it.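

Chloro in place of hydrogen, ortho to the chloro group already on the ring, is the first change to that ring seen here, and it shows that this position matters for the amide series in this assay, with an at least 5.0-fold lower number from compound 2 to compound 3 (0.69 log units; beyond the scatter). Compound 2's reported value is a limit of the assay and not a number, so the full size of this step cannot be read: the limit of > 2000 nM in this assay, at which 1 of the 3 values shown sits. The added chloro still does not close the whole gap to the urea, which remains beyond the scatter, with a 4.4-fold higher number from compound 1 to compound 3 (0.65 log units; beyond the scatter).

Going by these compounds, whether a methyl or a methoxy group in the same place would give a similar gain remains open, as does whether the effect needs the chloro group already on the ring. On these data alone, it is also open whether the urea of compound 1 would gain in the same way from the change from 4-chlorophenyl to 3,4-dichlorophenyl, so these compounds cannot show whether the effect of the added chloro carries over from the amide to the urea.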